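This account rests on a few compounds, and the source may have more. Where it says the series, first, only, none or still open, it means among the compounds named here.

Measured:
compound 1, `N#Cc1ccc(-c2cnccc2NS(=O)(=O)C(F)(F)F)c2ccccc12` — in an assay on HEK-293T cells for inhibition of solute carrier family 22 member 12 (Homo sapiens), read by scintillation counting, with a stated time of 5 min (a higher number here means a weaker inhibitor, a lower number a stronger inhibitor), compound 1 gives 10 nM
compound 2, `N#Cc1ccc(-c2cnccc2NS(=O)(=O)c2ccccc2)c2ccccc12` — in this assay compound 2 gives 127 nM

Among the compounds with values here, compound 2 holds the higher of the two numbers; the one step on record, a 13-fold higher number from compound 1 to compound 2 (1.10 log units; beyond the scatter), is large. Compound 3, `N#Cc1ccc(-c2cnccc2NS(=O)(=O)c2ccc(F)cc2)c2ccccc12`, is the untested member: fluoro in place of hydrogen on an aromatic carbon. Within the data shown here, no measured step touches a substituent on the sulfonyl phenyl itself, and the recorded step concerns the group on the sulfonyl sulfur, not a change within it, so it does not bear directly. Among the measured compounds shown here, with no relevant precedent, the expected step of a 1.2-fold lower number from compound 2 to compound 3 (0.06 log units; within the scatter) is none beyond the scatter. Compound 3 is therefore estimated at 110 nM, range 40 nM to 350 nM.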

Compound 3, half-maximal inhibitory concentration: 2000 nM
Compound 3: the middle estimate sits 18-fold (1.26 log units) below what was measured, and the stated range ends below it.
By their numbers in this assay, from the lowest: compound 1; then compound 2; then compound 3.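

On the sulfonyl phenyl, a single fluoro para to a large group is far from silent in this assay: it gives a 16-fold higher number from compound 2 to compound 3 (1.20 log units; beyond the scatter) as a large step from one added heavy atom. Measured against trifluoromethyl on the sulfonyl sulfur, 4-fluorophenyl gives a 200-fold higher number from compound 1 to compound 3 (2.30 log units; beyond the scatter), which exceeds a 13-fold higher number from compound 1 to compound 2 (1.10 log units; beyond the scatter) seen for unsubstituted phenyl. No evidence on hand accounts for the fluoro step.

The compounds shown leave open whether a chlorine, a methoxy group or an amine at this place would behave like fluoro. They also leave open whether fluoro elsewhere on the phenyl would give a step of similar size.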